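Leukotriene C4 synthase series: halogenated aryl on the aminopyridine nitrogen

A few compounds are considered here, and "the series" means these few. Any claim that something is new, unique, unknown or untested is made for them only; others in the source may bear on it.

Measured compounds:
- compound 1, `COc1cc(N(CC2CC2)c2ccccc2)cnc1C(=O)[C@H]1C[C@@H]1C(=O)O`: 158 nM
- compound 2, `COc1cc(N(CC(C)C)c2ccc(F)c3ccccc23)cnc1C(=O)[C@H]1C[C@@H]1C(=O)O`: 0.381 nM

In an assay for inhibition of leukotriene C4 synthase (Homo sapiens), read by LC-MS, with stated times of 15 min and 30 min (a lower number here means a stronger inhibitor, a higher number a weaker inhibitor), compound 1 gives 158 nM, the higher of the two numbers recorded so far. Compound 2 gives 0.381 nM in this assay, a far lower number, and the gap between the two lies well beyond the scatter of repeat measurements. Within the data shown here, no single-point step between measured compounds is available, so the size of any one change is not yet known.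

Compound 3, `COc1cc(N(CC2CC2)c2ccc(F)c(Cl)c2)cnc1C(=O)[C@H]1C[C@@H]1C(=O)O`, has not been measured. It differs from compound 1 by 3-chloro-4-fluorophenyl in place of phenyl on a nitrogen on an aromatic ring. The expectation is that compound 3 gives a lower number than compound 1 in this assay, by a step of an 11-fold lower number from compound 1 to compound 3 (1.02 log units; beyond the scatter), a change clearly beyond the scatter. Compound 3 is estimated at 15 nM, with a range of 3 nM to 70 nM.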

Compound 3, half-maximal inhibitory concentration: 5.26 nM
The estimate for compound 3 lay 2.9-fold (0.46 log units) above the measured number; low and high end bracket the measured number.
By their numbers in this assay, from the lowest: compound 2; then compound 3; then compound 1.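

Replacing the phenyl group with 3-chloro-4-fluorophenyl gives a 30-fold lower number from compound 1 to compound 3 (1.48 log units; beyond the scatter) in this assay. Among these compounds, this is the first single-place step, and it shows that this position responds strongly to substitution on the aryl ring, with only one chlorine and one fluorine added and no hydrogen-bond donor or acceptor entering. No measurement offered here accounts for the size of this step.

Going by these compounds, it remains open whether the chlorine or the fluorine alone would give the same step, or whether a nitrile or a trifluoromethyl group could stand in for either halogen. Compound 3 differs from compound 2 in more than one place, so what sets the value of compound 2, 0.381 nM, apart cannot be assigned to any single group.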